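Amide variation on the sulfonamide piperidine series

The source may report more compounds than this note shows. Statements on the series, on what has been measured and on what is new or still open speak of the compounds shown alone.

Measured so far in an assay on U2OS cells for inhibition of secreted frizzled-related protein 1 (Homo sapiens), read by a luciferase reporter, with a stated time of 18 h; a lower number here means that less compound is needed, a higher number that more compound is needed for the effect:
Compound 1 `O=C(c1ccc(C(F)(F)F)cc1)N1CCC(NS(=O)(=O)c2cc(S(=O)(=O)c3ccccc3)ccc2C(F)(F)F)CC1` gives 970 nM.
Compound 2 `CN(C)c1ccc(C(=O)N2CCC(NS(=O)(=O)c3cc(S(=O)(=O)c4ccccc4)ccc3C(F)(F)F)CC2)cn1` gives 70 nM.
Compound 3 `O=C(O)CCCC(=O)N1CCC(NS(=O)(=O)c2cc(S(=O)(=O)c3ccccc3)ccc2C(F)(F)F)CC1` gives 570 nM.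

Compound 3 sits second highest of the three numbers: its gap to compound 1 is within the scatter, while compound 2 stands well below it, as an 8.1-fold higher number from compound 2 to compound 3 (0.91 log units; beyond the scatter) shows. Compound 4 `CC(C)(C)OC(=O)N1CC[C@@H](C(=O)N2CCC(NS(=O)(=O)c3cc(S(=O)(=O)c4ccccc4)ccc3C(F)(F)F)CC2)C1` differs from compound 3 only in the group on the amide carbonyl: 1-(tert-butoxycarbonyl)pyrrolidin-3-yl in place of 3-carboxypropyl on a carbonyl carbon. For the measured compounds named here, the only steps that bear on this position are a 1.7-fold lower number from compound 1 to compound 3 (0.23 log units; within the scatter), which was within the scatter, and a 14-fold lower number from compound 1 to compound 2 (1.14 log units; beyond the scatter), which was large. Going by the values given here, no measured step involves a saturated ring with a carbamate at this position, so the expected step of a 1.1-fold lower number from compound 3 to compound 4 (0.06 log units; within the scatter) in this assay is small, with wide uncertainty. Compound 4 is estimated at 500 nM, within 150 nM to 2000 nM.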

Compound 4, half-maximal effective concentration: 80 nM
Compound 4: the middle estimate sits 6.3-fold (0.80 log units) above what was measured; the measured number lies below the stated range.
By their numbers in this assay, from the lowest: compounds 2 and 4 (each within the scatter of the next); then compounds 3 and 1 (each within the scatter of the next).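

At this position, in this assay, the 1-(tert-butoxycarbonyl)pyrrolidin-3-yl group gives a low number with no aromatic ring on the carbonyl carbon, beyond the scatter against both 3-carboxypropyl (a 7.1-fold lower number from compound 3 to compound 4 (0.85 log units; beyond the scatter)) and 4-(trifluoromethyl)phenyl (a 12-fold lower number from compound 1 to compound 4 (1.08 log units; beyond the scatter)). It stands within the scatter of 6-(dimethylamino)pyridin-3-yl (a 1.1-fold higher number from compound 2 to compound 4 (0.06 log units; within the scatter)), so among these compounds a number of that size does not depend on an aromatic ring here. No measurement at hand explains these steps.

Still open, from the compounds shown here alone, is whether the free pyrrolidine amine, without the tert-butoxycarbonyl group, holds the number of compound 4. The role of the defined stereocentre, which the opposite enantiomer would test, is also unresolved.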